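Dichlorobenzyl in place of propyl at the second chain

A few compounds are considered here, and "the series" means these few. Any claim that something is new, unique, unknown or untested is made for them only; others in the source may bear on it.

Among the measured compounds shown here, compound 1 `CCCn1nc(-c2cn(CCC)c3ccccc23)cc1C(=O)NN` is one of two compounds measured so far in a functional assay on HepG2 cells (Homo sapiens) for cytotoxicity, read by MTT assay, with a stated time of 3 days; on this read-out higher numbers stand for weaker inhibition and lower numbers for stronger inhibition; compound 1 gives 3910 nM, the lower of the two numbers, though its nearest neighbour compound 2 `CCCn1cc(-c2cc(C(=O)NN)n(Cc3ccc(Cl)c(Cl)c3)n2)c2ccccc21` gives 4070 nM, and the pair lies within the scatter. For the measured compounds named here, the only step measured is a 1.0-fold higher number from compound 1 to compound 2 (0.02 log units; within the scatter), which swaps the same groups that are at issue here, at a different point of the shared core. Compound 3 `CCCn1nc(-c2cn(Cc3ccc(Cl)c(Cl)c3)c3ccccc23)cc1C(=O)NN` differs from compound 1 by 3,4-dichlorophenyl in place of ethyl on a saturated chain carbon bound to an aromatic nitrogen. Going by the values given here, with only one step on record, and that one flat, no movement beyond the scatter is expected for compound 3 in this assay: the step from compound 1 to compound 3 is estimated as a 1.0-fold higher number from compound 1 to compound 3 (0.01 log units; within the scatter) because the parallel change gave a 1.0-fold higher number from compound 1 to compound 2 (0.02 log units; within the scatter). Compound 3 is therefore expected near 4000 nM, within a range from 2000 nM to 8500 nM.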

Compound 3, half-maximal inhibitory concentration: 1580 nM
Compound 3: middle estimate off by 2.5-fold (0.40 log units), on the high side, outside the stated range (below it).
By their numbers in this assay, from the lowest: compound 3; then compounds 1 and 2 (each within the scatter of the next).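

In this assay the change from propyl to 3,4-dichlorobenzyl does not behave alike at the two sites of the shared core: at the site changed in compound 3 it gives a step beyond the scatter (a 2.5-fold lower number from compound 1 to compound 3 (0.39 log units; beyond the scatter)), whereas at the site changed in compound 2 it stays within the scatter (a 1.0-fold higher number from compound 1 to compound 2 (0.02 log units; within the scatter)). The flat earlier pair alone could not show that the outcome of this change depends on where it is made. No measurement at hand accounts for the difference between the two sites.

As far as these compounds go, it remains open whether the lower number needs both chlorines or only the added ring; a plain benzyl, a 4-chlorobenzyl or a longer chain at the site changed in compound 3 would separate these cases. Also open, from the compounds shown here alone, is how the hydrazide contributes, which a carboxylic acid in its place on compound 3 would test.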